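Dimethylamino in place of acetamido: an expectation for compound 4

The source may report more compounds than this note shows. Statements on the series, on what has been measured and on what is new or still open speak of the compounds shown alone.

Measured compounds:
compound 1, `Cc1nc2c(OCc3ccc(F)cc3)cccn2c1N`: 95%
compound 2, `Cc1ccn2c(N)c(C)nc2c1OCc1ccccc1`: 60%
compound 3, `CC(=O)Nc1c(C)nc2c(OCc3ccccc3)cccn12`: 93%

All three were tested in a functional assay on the whole organism with Rattus norvegicus as the target, at a dose of 40 mg/kg by the intraperitoneal route; on this read-out lower numbers stand for less inhibition and higher numbers for more inhibition at the one dose given (going by the name of the read-out). Compound 3 stands second highest of the three numbers; compound 1 gives a value within the scatter of compound 3, while compound 2 lies beyond the scatter below it. Compound 4, `Cc1nc2c(OCc3ccccc3)cccn2c1N(C)C`, is not yet measured. It differs from compound 3 by dimethylamino in place of acetamido on an aromatic carbon. Among the measured compounds shown here, no measured pair shows this change, so the size of its step is unknown. Compound 1 and compound 3 both give high values, whereas compound 2 shows how far the read-out can fall with another change. A modest downward step is expected, a number 13 percentage points lower from compound 3 to compound 4 (beyond the scatter), with wide uncertainty. Compound 4 is estimated at 80%, between 45% and 98%.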

Compound 4, a percentage reported as inhibition, in the whole organism at one dose (the size of the read-out at that dose, not a potency): 76%
Estimate against measurement, compound 4: 4 percentage points above; the measured number falls inside the stated range.
By their numbers in this assay, from the lowest: compound 2; then compound 4; then compounds 3 and 1 (each within the scatter of the next).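

Dimethylamino in place of acetamido on an aromatic carbon gives the first readable step at this position in this assay: a number 17 percentage points lower from compound 3 to compound 4 (beyond the scatter). The group here therefore matters to the read-out, although the step is modest and compound 4 still gives 76% at the one dose. Nothing available gives a reason for this step. The compounds shown leave open what a methylamino group or a longer amide chain would give at this position. They also leave open whether the same step would appear on the core of compound 1.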